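The source may hold more compounds than are shown below. What is called first, only, known or untested is meant among the compounds shown, and "the series" means these compounds.

Compound 2 `COc1ccc(S(=O)(=O)N(C)c2ccc3[nH]c(-c4n[nH]c5ccccc45)cc3n2)cc1` was tested in a functional assay on A549 cells (Homo sapiens) for antiproliferative activity, read by MTT assay, with a stated time of 72 h (on this read-out higher numbers stand for weaker inhibition and lower numbers for stronger inhibition), and gave 24300 nM. Going by the values given here, the only other measured compound, compound 1 `CN(C(=O)c1ccccc1)c1ccc2[nH]c(-c3n[nH]c4ccccc34)cc2n1`, gave 13800 nM in this assay; the two numbers lie within the usual scatter of each other, so the set holds no measured step between compounds at all. Compound 3 `CN(c1ccc2[nH]c(-c3n[nH]c4ccccc34)cc2n1)S(=O)(=O)c1ccc(OC(F)(F)F)cc1` has not yet been measured. It differs from compound 2 in a single place: trifluoromethyl in place of methyl on an oxygen on an aromatic ring. Among the compounds with values here, with no measured step to lean on, nothing in the data shows what this change does in this assay, and the expectation for compound 3 rests on compound 2 alone, whose value 24300 nM sets the starting point. In this assay the expected change is a 1.5-fold lower number from compound 2 to compound 3 (0.18 log units; within the scatter), which is no step beyond the scatter. Compound 3 is therefore estimated at 16000 nM, with a range from 5000 nM to 50000 nM.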

Compound 3, half-maximal inhibitory concentration: 8000 nM
Compound 3: middle estimate off by 2.0-fold (0.30 log units), on the high side; measured number inside the range.
By their numbers in this assay, from the lowest: compounds 3, 1 and 2 (each within the scatter of the next, the first and the last beyond it).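

Trifluoromethyl in place of methyl on an oxygen on an aromatic ring gives a 3.0-fold lower number from compound 2 to compound 3 (0.48 log units; beyond the scatter) in this assay, the first step in this set. Going by these compounds alone, the earlier compounds offered no step at all, so this is the first sign that the group on this oxygen can shift the read-out, although the step is only modest and compound 3 still gives 8000 nM. No measurement at hand speaks to the reason for this step.

The compounds shown leave open whether the lower number is specific to trifluoromethyl or would also come with an ethyl group or a longer chain on that oxygen. They also leave open what an amine or a carboxylic acid in place of the whole 4-(trifluoromethoxy)phenyl group would do.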